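The source may hold more compounds than are shown below. What is called first, only, known or untested is meant among the compounds shown, and "the series" means these compounds.

Working notes on the series. In a functional assay on ECa-109 cells for inhibition, with ECa-109 cell line (Homo sapiens) as the target, read by MTT assay, with a stated time of 72 h (a lower number here means a stronger inhibitor, a higher number a weaker inhibitor), compound 1 `CN1CCN(C(=S)SCCCOc2ccc(C(=O)/C=C/c3ccc(Cl)cc3)cc2)CC1` gives 34200 nM; this is the highest of the two numbers that stand, with compound 3 `CN1CCN(C(=S)SCCCOc2ccc(C(=O)/C=C/c3cc(Cl)cc(Cl)c3)cc2)CC1` at 12400 nM the nearest, the step being a 2.8-fold lower number from compound 1 to compound 3 (0.44 log units; beyond the scatter). Compound 2 `COc1ccc(/C=C/C(=O)c2ccc(OCCCSC(=S)N3CCN(C)CC3)cc2)cc1` shows only a limit in this assay, > 100000 nM. The step from compound 1 to compound 2 is an at least 2.9-fold higher number from compound 1 to compound 2 (0.46 log units; beyond the scatter), and that from compound 2 to compound 3 is an at least 8.0-fold lower number from compound 2 to compound 3 (0.90 log units; beyond the scatter); both rest on the limit of compound 2 (the limit of > 100000 nM in this assay, at which 1 of the 3 values shown sits).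

Compound 4 `O=C(/C=C/c1ccc(Cl)cc1)c1ccc(OCCCSC(=S)N2CCCCC2)cc1` is yet to be measured. It differs from compound 1 in one place: piperidin-1-yl in place of 4-methylpiperazin-1-yl on a thiocarbonyl carbon. Among the measured compounds shown here, none of the measured steps touches this part of the shared core; each concerns the aromatic ring on the double-bonded chain carbon, so no measured step bears directly on the change. Without guidance the expectation for this assay is a step of a 1.1-fold lower number from compound 1 to compound 4 (0.06 log units; within the scatter) from compound 1, not beyond the scatter in either direction. Compound 4 is therefore expected to give about 30000 nM in this assay, with a range from 9000 nM to 100000 nM.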

Compound 4, half-maximal inhibitory concentration: 42600 nM
Beside the measured number, compound 4's estimate is 1.4-fold (0.15 log units) below it, and the stated range covers the measured number.
By their numbers in this assay, from the lowest: compound 3; then compounds 1 and 4 (each within the scatter of the next). At a limit, above all of these: compound 2.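

Every earlier step concerned the aromatic ring on the double-bonded chain carbon, whereas this one is on the thiocarbonyl carbon: in this assay, piperidin-1-yl in place of 4-methylpiperazin-1-yl gives a 1.2-fold higher number from compound 1 to compound 4 (0.10 log units; within the scatter). Compound 1 and compound 4 therefore cannot be told apart, so with the 4-chlorophenyl group in place, the methyl-bearing ring nitrogen of 4-methylpiperazin-1-yl is not required to keep this level of inhibition. Nothing at hand bears on the reason for this outcome.

Among the compounds shown here, only this one pair spans the position, so it remains open whether the same holds with the 3,5-dichlorophenyl group of compound 3. Also open, as far as these compounds go, is how a morpholine ring, an open-chain diethylamine or a piperazine with a free ring amine would read on the thiocarbonyl carbon.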